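The source may report more compounds than this note shows. Statements on the series, on what has been measured and on what is new or still open speak of the compounds shown alone.

Measured compounds:
compound 1 `C=CC1=C(C(=O)Nc2ccc(OCC)cc2)C(c2ccc(OC)cc2)OC1` — in a functional assay on SW480 cells (Homo sapiens) for cytotoxicity, read by MTT assay, with a stated time of 24 h (a higher number here means a weaker inhibitor, a lower number a stronger inhibitor), compound 1 gives > 100000 nM, a limit of the assay rather than a number.
compound 2 `C=CC1=C(C(=O)NCC(C)C)C(c2ccc(OC)cc2)OC1` — in this assay compound 2 gives > 100000 nM, again a limit rather than a number.

Compound 2 thus stands at the upper edge of what this assay reports, and it shares that position with compound 1, as the limit of > 100000 nM in this assay, at which 2 of the 2 values shown sit, records. Going by the values given here, the one step between measured compounds, a step that the two limits leave unreadable from compound 1 to compound 2, cannot be read in size or direction, since both ends are limits.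

Compound 3 `C=CC1=C(C(=O)NCc2ccc(C)cc2)C(c2ccc(OC)cc2)OC1` differs from compound 2 by 4-methylphenyl in place of isopropyl on a saturated chain carbon bound to an amide-type nitrogen. Among the compounds with values here, no measured step bears on this change in a readable way; the only comparison available, a step that the two limits leave unreadable from compound 1 to compound 2, shows merely that exchanging one amide substituent for another left both compounds at the limit. With no evidence of any group on the amide nitrogen side producing a measurable number, the expectation for compound 3 is that it also sits at the limit, giving no step beyond the scatter. The estimate for compound 3 in this assay is 100000 nM, within 30000 nM to 300000 nM, which is an expected step of a number no higher from compound 2 to compound 3 (the limit leaves the size open) from compound 2.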

Compound 3, half-maximal inhibitory concentration: 31700 nM
Compound 3: the middle estimate sits 3.2-fold (0.50 log units) above what was measured, within the range that was stated.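

In this assay, the amide substituent gives its first readable number: 4-methylphenyl in place of isopropyl on a saturated chain carbon bound to an amide-type nitrogen brings an at least 3.1-fold lower number from compound 2 to compound 3 (0.49 log units; beyond the scatter). Carrying an aromatic ring on the amide-type nitrogen is not enough in itself, since 4-methylbenzyl in place of 4-ethoxyphenyl still brings an at least 3.1-fold lower number from compound 1 to compound 3 (0.49 log units; beyond the scatter). Both steps start from a limit rather than a number, so they fix only a minimum size and leave the full size open: the limit of > 100000 nM in this assay, at which 2 of the 3 values shown sit.

The compounds shown leave open whether the lower number rests on the benzyl unit as a whole or on its methyl group, a question that a plain benzyl group on the amide-type nitrogen would separate. Also open, on these data alone, is how a 2-phenylethyl group on that nitrogen, or a carboxylic acid in place of the methyl group of the 4-methylbenzyl, would read in this assay.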